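Swapping methoxy for trifluoromethyl in a urea series

This account rests on a few compounds, and the source may have more. Where it says the series, first, only, none or still open, it means among the compounds named here.

Measured compounds:
compound 1 `CCNc1cc(-c2ccc(NC(=O)Nc3ccccc3Cl)cc2C(F)(F)F)ccn1`, 3680 nM
compound 2 `CCNc1cc(-c2ccc(NC(=O)Nc3ccccc3Cl)cc2OC)ccn1`, 9940 nM
compound 3 `CCNc1cc(-c2ccc(NC(=O)Nc3ccc(OC)cc3)cc2F)ccn1`, 14100 nM

All three were tested in a functional assay on MCF7 cells (Homo sapiens) for cytotoxicity, read by MTT assay, with a stated time of 24 h; on this read-out higher numbers stand for weaker inhibition and lower numbers for stronger inhibition. Compound 2 and compound 1 differ in one place only: trifluoromethyl in place of methoxy on an aromatic carbon. That single change produced a 2.7-fold lower number from compound 2 to compound 1 (0.43 log units; beyond the scatter). Compound 3 stands on a different core from compound 2; the difference between the two cores is not broken down here, and their two numbers lie within the scatter of each other.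

Compound 4 `CCNc1cc(-c2ccc(NC(=O)Nc3ccc(C(F)(F)F)cc3)cc2F)ccn1` has not yet been measured. It differs from compound 3 by trifluoromethyl in place of methoxy on an aromatic carbon. This is the same kind of change as from compound 2 to compound 1, but not the same: in compound 1 the entering group sits ortho to a 2-(ethylamino)pyridin-4-yl group and meta to a large group, whereas in compound 4 it sits para to a large group. Among the compounds with values here, because a 2.7-fold lower number from compound 2 to compound 1 (0.43 log units; beyond the scatter) is the only measured example of this change, and it sits elsewhere on the molecule, a step of similar size but with wide uncertainty is expected, a 2.0-fold lower number from compound 3 to compound 4 (0.30 log units; within the scatter). Compound 4 is therefore estimated at 7000 nM, within a range from 3000 nM to 16000 nM.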

Compound 4, half-maximal inhibitory concentration: 8020 nM
Estimate against measurement, compound 4: 1.1-fold (0.06 log units) below; the measured number falls inside the stated range.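

In this assay putting trifluoromethyl in place of methoxy on the second core gives a 1.8-fold lower number from compound 3 to compound 4 (0.25 log units; within the scatter) and so, taken alone, this step is not a clear change. Set beside the earlier example, the two steps run in the same direction and their sizes cannot be told apart: the same change on two cores in this assay, a 2.7-fold lower number (0.43 log units; beyond the scatter) from compound 2 to compound 1 and a 1.8-fold lower number (0.25 log units; within the scatter) from compound 3 to compound 4, 1.5-fold (0.19 log units) apart, within the scatter of two such steps. Nothing here speaks against carrying the change from one core to the other, but it is not shown that the drop carries over: the step on the second core is within the scatter, the group sits at a different place in the two pairs, and two pairs make no rule.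

The compounds shown leave open whether another group in the same place, such as a nitrile or a carboxylic acid, would move the number further than trifluoromethyl does. They also leave open whether the swap would give matching steps if made at one and the same place on both cores.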